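Replacing a Ring Ester with a Hydroxy-Bearing Chain

A few compounds are considered here, and "the series" means these few. Any claim that something is new, unique, unknown or untested is made for them only; others in the source may bear on it.

Compound 1: `CC[C@@](C)(O)CC(=O)O[C@H](CC=C(C)C)C1=CC(=O)c2c(O)ccc(O)c2C1=O` — 17900 nM
Compound 2: `CC(C)=CC[C@@H](OC(=O)C1CCOC1)C1=CC(=O)c2c(O)ccc(O)c2C1=O` — 73500 nM

Both compounds were tested in a functional assay on HeLa cells (Homo sapiens) for cytotoxicity, read by MTT assay; a higher number here means a weaker inhibitor, a lower number a stronger inhibitor. Among the compounds with values here, of the two numbers measured so far, compound 2 has the higher one; its nearest neighbour is compound 1, and the step of a 4.1-fold higher number from compound 1 to compound 2 (0.61 log units; beyond the scatter) separates them. Compound 3, `CCCCC(C)(O)CC(=O)O[C@H](CC=C(C)C)C1=CC(=O)c2c(O)ccc(O)c2C1=O`, has not yet been measured. Within the data shown here, it differs from compound 2 in one place: 2-hydroxy-2-methylhexyl in place of oxolan-3-yl on a carbonyl carbon The single measured step bears directly on this change, because a 4.1-fold higher number from compound 1 to compound 2 (0.61 log units; beyond the scatter) went the opposite way, from a hydroxy-bearing chain to the oxolan-3-yl ring, and raised the number modestly. Compound 3 restores a hydroxy-bearing chain of the same kind, only with a longer chain, so the number is expected to fall back toward that of compound 1. For compound 3 the expected step is a 4.6-fold lower number from compound 2 to compound 3 (0.66 log units; beyond the scatter). Compound 3 is estimated at 16000 nM, with a range from 6000 nM to 40000 nM.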

Compound 3, half-maximal inhibitory concentration: 60600 nM
The estimate for compound 3 lay 3.8-fold (0.58 log units) below the measured number; measured number above the stated range.
By their numbers in this assay, from the lowest: compound 1; then compounds 3 and 2 (each within the scatter of the next).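

In this assay, a hydroxy-bearing chain on this carbonyl carbon does not by itself restore the lower number of compound 1: 2-hydroxy-2-methylhexyl in place of oxolan-3-yl gives only a change within the scatter (a 1.2-fold lower number from compound 2 to compound 3 (0.08 log units; within the scatter)). Between the two hydroxy-bearing chains, the longer 1-hydroxy-1-methylpentyl in place of 1-hydroxy-1-methylpropyl gives a step beyond the scatter (a 3.4-fold higher number from compound 1 to compound 3 (0.53 log units; beyond the scatter)), so among these three compounds, chain length matters here as well as the hydroxy group. No measurement is available to explain this result.

Still open, on these data alone, is how a shorter chain would compare at this place, and whether an amine in place of the hydroxy group on the 1-methylpropyl chain would keep the number of compound 1.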